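Bromo for methoxy on the chalcone aryl ring

A few compounds are considered here, and "the series" means these few. Any claim that something is new, unique, unknown or untested is made for them only; others in the source may bear on it.

The series shares one core, shown by compound 1 `COc1ccc(/C=C/C(=O)c2c(C)[n+]([O-])c3ccccc3[n+]2[O-])cc1` and compound 2 `Cc1c(C(=O)/C=C/c2ccc(Cl)c(Cl)c2)[n+]([O-])c2ccccc2[n+]1[O-]`, and is followed in a functional assay on HSC-3 cells (Homo sapiens) for cytotoxicity, with a stated time of 48 h; a higher number here means that more compound is tolerated, a lower number that less compound is tolerated. Compound 1 gives 23000 nM in this assay, the lowest of the two numbers recorded; compound 2 gives 84000 nM. Among the measured compounds shown here, the only step between measured compounds is a 3.7-fold higher number from compound 1 to compound 2 (0.56 log units; beyond the scatter), so the measured record contains a single exchange of the aryl substituents and nothing else.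

Compound 3 `Cc1c(C(=O)/C=C/c2ccc(Br)cc2)[n+]([O-])c2ccccc2[n+]1[O-]` takes the same route in a different form: bromo in place of methoxy on an aromatic carbon. The step from compound 1 to compound 2 bears on it, since both replace the methoxy-bearing ring with a halogenated one, and that step was modest and beyond the scatter. For the measured compounds named here, compound 3 carries one halogen rather than two, so the expected step in this assay is a rise of similar or smaller size than the one seen for compound 2, and it may not clear the scatter.

For compound 3 the expected step is a 2.0-fold higher number from compound 1 to compound 3 (0.29 log units; within the scatter), which gives an estimated 45000 nM with a range from 15000 nM to 130000 nM.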

Compound 3, half-maximal cytotoxic concentration: 56000 nM
Beside the measured number, compound 3's estimate is 1.2-fold (0.09 log units) below it; measured number inside the range.
By their numbers in this assay, from the lowest: compound 1; then compounds 3 and 2 (each within the scatter of the next).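

In this assay, bromo in place of methoxy on an aromatic carbon, para to a large group, gives a 2.4-fold higher number from compound 1 to compound 3 (0.39 log units; beyond the scatter). This shows that a change at this one position, with a single halogen, is enough to move the number beyond the scatter, which the earlier exchange of 4-methoxyphenyl for 3,4-dichlorophenyl could not show, as that exchange also added a second chlorine. The further step, a 1.5-fold lower number from compound 2 to compound 3 (0.18 log units; within the scatter), leaves 4-bromophenyl and 3,4-dichlorophenyl indistinguishable in this assay, and no supporting evidence bears on why the number moves with this exchange.

The compounds shown leave open whether the shift follows from losing the methoxy or from gaining a halogen, as every change here does both or replaces the whole substituted ring. A plain hydrogen, a fluoro or an amine at the same position on the aromatic ring would help separate those two readings, and a longer chain in place of the methoxy would show whether other ethers keep the number of compound 1.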